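This account rests on a few compounds, and the source may have more. Where it says the series, first, only, none or still open, it means among the compounds named here.

Measured so far:
compound 1 `COc1ncc(C#Cc2ccc(C)cc2)cn1` — "not active" (no number reported)
compound 2 `CNc1ncc(C#Cc2cccc(C)c2)cn1` — 21100 nM

Of the compounds shown here, two have been tested in an assay on HEK293 cells for positive allosteric modulation of metabotropic glutamate receptor 5 (Rattus norvegicus); a lower number here means that less compound is needed, a higher number that more compound is needed for the effect. Compound 1 is reported as "not active" (no number reported), so no number stands for it. Compound 2 gives 21100 nM in this assay, a weak effect. Among the measured compounds shown here, compound 1 has no number, and no step between the two measured compounds can be drawn. Compound 2 differs from compound 1 in more than one place, so its value alone does not show what the change at hand will do.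

The next compound, compound 3 `Cc1ccc(C#Cc2cnc(C(C)(C)C)nc2)cc1`, is built from compound 1 by one change: tert-butyl in place of methoxy on an aromatic carbon. With compound 1 showing no activity, the step is expected to stay modest at best, most likely with compound 3 again weak or without a number. Compound 3 is estimated at 15000 nM in this assay, within a range of 3000 nM to 60000 nM.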

Compound 3, half-maximal effective concentration: "not active" (no number reported)
Compound 3: no number reported; there is nothing to compare the estimate with.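

In this assay compound 1 and compound 3 both come without a number, so no step can be read between them. Nothing available here bears on this result. The compounds shown leave open whether any group at this place gives a measurable effect on the shared core.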